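The compounds below may be only part of what the source reports. "The series", "measured", "known", "first", "only" and "open" are said of these compounds alone.

In a functional assay on HL-60 cells (Homo sapiens) for inhibition, read by MTT assay, with a stated time of 72 h, tested at 30 uM (on this read-out higher numbers stand for more inhibition of growth at the one concentration tested and lower numbers for less inhibition of growth), two compounds have been measured so far. Compound 1 `C=CCc1cc(O)c(O)c(CN2CCC(C)CC2)c1` gives 91.1%. Compound 2 `C=CCc1ccc(OCc2cn(-c3ccc(C#N)cc3)nn2)c(O)c1` gives 20.8%, the lower of the two numbers, and the gap between them lies well beyond the scatter. Compound 3 `C=CCc1ccc(OCc2cn(-c3ccc(OC)cc3)nn2)c(O)c1` is compound 2 with a single change: methoxy in place of cyano on an aromatic carbon. In plain terms, methoxy stands in place of cyano on an aromatic carbon, which turns the 4-cyanophenyl into 4-methoxyphenyl. Among the compounds with values here, no measured pair shows what this swap does, so the expectation starts from compound 2 at 20.8% and allows only a small upward move, most likely none beyond the scatter. The estimated step is a number 5.2 percentage points higher from compound 2 to compound 3 (within the scatter). In this assay, the expected value for compound 3 is 26%, with an estimated range from 8% to 50%.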

Compound 3, percent growth inhibition at one concentration: 21.3%
Compound 3: middle estimate off by 4.7 percentage points, on the high side, within the range that was stated.
By their numbers in this assay, from the lowest: compounds 2 and 3 (each within the scatter of the next); then compound 1.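

In this assay, placing methoxy where cyano stood gives a number 0.5 percentage points higher from compound 2 to compound 3 (within the scatter), so on this aromatic carbon, para to a large group, the measurement does not tell the two groups apart. Within the data shown here, this is the first pair that differs in one place, which makes it the first direct look at what a change at this position does. Nothing measured here offers a cause for this result.

On these data alone, whether an amine or a carboxylic acid at the same position would also stay level with compound 2 and compound 3 remains open. Among these compounds, compound 1 differs from both of them in more than one place, so no step to it can be read, and what separates its much higher number from theirs also remains open.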